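The compounds below may be only part of what the source reports. "The series", "measured", "known", "first", "only" and "open" are said of these compounds alone.

Compound 1 `O=C(N/N=C/c1ccc(F)cc1)Nc1ccc(Oc2ccnc3[nH]ccc23)c(F)c1` gives 680 nM in a functional assay on A549 cells (Homo sapiens) for antiproliferative activity, read by MTT assay, with a stated time of 72 h; a lower number here means a stronger inhibitor, a higher number a weaker inhibitor.
Compound 2 `COc1cc(/C=N/NC(=O)Nc2ccc(Oc3ccnc4[nH]ccc34)c(F)c2)cc(OC)c1OC` gives 34100 nM in this assay.
Compound 3 `O=C(N/N=C/c1ccc(F)cc1)Nc1ccc(Oc2ccnc3[nH]ccc23)cc1` gives 1430 nM in this assay.

Compound 1 has the lowest number of the three. For the measured compounds named here, the only single-place step known starts from it: a 2.1-fold higher number from compound 1 to compound 3 (0.32 log units; beyond the scatter). Compound 2 is not joined to compound 1 by a single step; their two values merely show that exchanging the group on the carbon with a double bond to nitrogen can move the result a long way. Compound 4 `CN(C)CCn1cccc1/C=N/NC(=O)Nc1ccc(Oc2ccnc3[nH]ccc23)c(F)c1` differs from compound 1 at that same carbon: 1-(2-(dimethylamino)ethyl)-1H-pyrrol-2-yl in place of 4-fluorophenyl on a carbon with a double bond to nitrogen. Going by the values given here, no measured step covers this exchange, so there is no direct guide, and the spread between compound 1 and compound 2 warns that the outcome is open. Compound 4 is therefore expected to land near 2000 nM, within a range from 300 nM to 15000 nM, which as an expected step reads a 2.9-fold higher number from compound 1 to compound 4 (0.47 log units; beyond the scatter).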

Compound 4, half-maximal inhibitory concentration: "not active" (no number reported)
No number was reported for compound 4; no gap can be computed for the estimate.
By their numbers in this assay, from the lowest: compound 1; then compound 3; then compound 2.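

For the compounds shown here, compound 4 is reported as not active in this assay without a number, so no step from compound 1 to compound 4 can be read. Nothing shown explains this result. From the compounds shown here alone, how other groups at that carbon would fare remains open.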